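A few compounds are considered here, and "the series" means these few. Any claim that something is new, unique, unknown or untested is made for them only; others in the source may bear on it.

Compound 1 `O=C(Nc1ccc(F)c(-c2nc3ncc(-c4cccc(F)c4F)cc3[nH]2)c1)N1CCCC1` gives 1830 nM
Compound 2 `Cc1nc(C)c(C(=O)Nc2ccc(F)c(-c3nc4ncc(-c5ccccc5Cl)cn4n3)c2)o1` gives 39300 nM

In an ADME assay on the whole organism (Mus musculus, strain Swiss Webster) for pharmacokinetics, read by LC-MS, at a dose of 50 mg/kg by the oral route (a lower number here means less compound in the circulation, a higher number more compound in the circulation at the dose given), compound 1 is the lower of the two measured compounds at 1830 nM, while compound 2 reaches 39300 nM, a gap beyond the usual scatter. Compound 3 `O=C(Nc1ccc(F)c(-c2nc3ncc(-c4cc(F)cc(F)c4)cc3[nH]2)c1)N1CCCC1` keeps all of compound 1 except one group, and the two have the same atoms, joined differently: 3,5-difluorophenyl in place of 2,3-difluorophenyl on an aromatic carbon. In words, 3,5-difluorophenyl stands in place of 2,3-difluorophenyl on an aromatic carbon. Within the data shown here, no two measured compounds differ in one place only, so nothing here shows directly what such a swap does in this assay. Compound 1 at 1830 nM is the closest guide, and no step beyond the scatter is expected, in either direction. The expected step is a 1.0-fold lower number from compound 1 to compound 3 (0.01 log units; within the scatter). For compound 3 the estimated maximal plasma concentration is 1800 nM, with an expected range of 500 nM to 6000 nM.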

Compound 3, maximal plasma concentration: 4800 nM
Beside the measured number, compound 3's estimate is 2.7-fold (0.43 log units) below it, within the range that was stated.
By their numbers in this assay, from the lowest: compound 1; then compound 3; then compound 2.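

Rearranging the two fluorines on the same ring, with no atom gained or lost, is enough to change the reading in this assay by a 2.6-fold higher number from compound 1 to compound 3 (0.42 log units; beyond the scatter), a modest move but one beyond the usual scatter. This position therefore responds to where the fluorines sit, with 3,5-difluorophenyl giving the higher number here, which the first two compounds could not show because they differ in more than one place. Nothing at hand explains why the rearrangement has this effect.

On these data alone, whether an unsubstituted phenyl, a methoxyphenyl or a pyridine ring at this position would raise or lower the number remains open. As far as these compounds go, it is also open whether the same fluorine rearrangement would have a similar effect if the pyrrolidine urea at the other end of the molecule were replaced by a morpholine urea.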